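This account rests on a few compounds, and the source may have more. Where it says the series, first, only, none or still open, it means among the compounds named here.

Compound 1, `Nc1ccc2[nH]c(-c3ccccc3)cc2c1`: in an assay on isolated protein for inhibition of Aromatase (Homo sapiens), read by fluorescence, using NADPH, with a stated time of 30 min, tested at 50 uM (on this read-out lower numbers stand for less inhibition and higher numbers for more inhibition at the one concentration tested (going by the name of the read-out)), compound 1 gives 41.4%.
Compound 2, `Cc1ccccc1-c1cc2cc([N+](=O)[O-])ccc2[nH]1`: in this assay compound 2 gives 71.5%.

Of the two measured compounds, compound 2 stands highest in this assay, and its gap to compound 1 lies beyond the usual scatter. Compound 3, `O=[N+]([O-])c1ccc2[nH]c(-c3ccccc3)cc2c1`, has not yet been measured. It differs from compound 2 in one place: hydrogen in place of methyl on an aromatic carbon. Among the measured compounds shown here, no two measured compounds differ by this change alone, so the data give no direct guide to its size. The step from compound 2 to compound 3 in this assay is therefore expected to be small, most likely none beyond the scatter, with a slight lean toward lower inhibition: a number 9.5 percentage points lower from compound 2 to compound 3 (within the scatter). Compound 3 is estimated at 62%, within a range from 40% to 80%.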

Compound 3, a percentage reported as inhibition, at one concentration (the size of the read-out at that concentration, not a potency): 77.7%
The estimate for compound 3 lay 15.7 percentage points below the measured number, and the stated range covers the measured number.
By their numbers in this assay, from the lowest: compound 1; then compounds 2 and 3 (each within the scatter of the next).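

In this assay, hydrogen in place of methyl on this aromatic carbon, ortho to a large group, gives a number 6.2 percentage points higher from compound 2 to compound 3 (within the scatter), so the methyl is not needed for the inhibition seen at this one concentration. Nitro in place of amino on an aromatic carbon gives a number 36.3 percentage points higher from compound 1 to compound 3 (beyond the scatter), the first single-place change in this set to clear the scatter, so in these compounds the choice between those two groups counts for far more than the choice between methyl and hydrogen. No measurement here explains why either step has the size it has.

The compounds shown leave open how a nitrile or a carboxylic acid would compare with the nitro at its carbon. They also leave open whether ethyl or chlorine in place of the methyl would stay within the scatter of compound 3.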